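One ring swapped for another in compound 3

This account rests on a few compounds, and the source may have more. Where it says the series, first, only, none or still open, it means among the compounds named here.

- Compound 1 `CN1CCN(CCCCn2c3c(c4ccccc42)C(=O)c2c[n+]([O-])c4ccccc4c2C3=O)CC1`: 100 nM
- Compound 2 `CN1CCN(CCCn2c3c(c4ccccc42)C(=O)c2c[n+]([O-])c4ccccc4c2C3=O)CC1`: 560 nM

In a functional assay on SH-SY5Y cells (Homo sapiens) for cytotoxicity, read by MTT assay, with a stated time of 72 h (a higher number here means a weaker inhibitor, a lower number a stronger inhibitor), compound 2 gives 560 nM, the higher of the two numbers, which makes it the weaker inhibitor of the pair. Compound 3 `O=C1c2c[n+]([O-])c3ccccc3c2C(=O)c2c1c1ccccc1n2CCCN1CCC(O)CC1` keeps the shared core and changes one group: 4-hydroxypiperidin-1-yl in place of 4-methylpiperazin-1-yl on a saturated chain carbon, three bonds along the chain from an aromatic nitrogen. In words, 4-hydroxypiperidin-1-yl stands in place of 4-methylpiperazin-1-yl, on the same chain. For the measured compounds named here, only one measured step is available, a 5.6-fold higher number from compound 1 to compound 2 (0.75 log units; beyond the scatter). That step alters the chain and leaves the ring alone, so it says little about this swap, although it shows that one small edit can move the number. Going by the values given here, no measured pair shows this ring swap directly. No step beyond the scatter is therefore expected in this assay, with wide uncertainty. The estimated step is a 1.1-fold higher number from compound 2 to compound 3 (0.03 log units; within the scatter). Compound 3 is expected at 600 nM, with an estimated range of 200 nM to 1800 nM.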

Compound 3, half-maximal inhibitory concentration: 130 nM
For compound 3 the middle estimate is 4.6-fold (0.66 log units) above the measured one; measured number below the stated range.
By their numbers in this assay, from the lowest: compounds 1 and 3 (each within the scatter of the next); then compound 2.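

Until now only the chain had changed, but the step of a 4.3-fold lower number from compound 2 to compound 3 (0.63 log units; beyond the scatter) in this assay shows that the ring at the end of the propyl chain also matters, and that replacing 4-methylpiperazin-1-yl with 4-hydroxypiperidin-1-yl gives a lower number. The step of a 1.3-fold higher number from compound 1 to compound 3 (0.11 log units; within the scatter) lies within the scatter, so the numbers for these two compounds, one with the longer chain and the other with the new ring, cannot be told apart. Nothing measured here explains why the ring swap moves the number.

The compounds shown leave open whether the hydroxyl group or the change in the ring atoms accounts for the step, which a plain piperidin-1-yl group on the same chain could help separate. They also leave open what 4-hydroxypiperidin-1-yl would do on the longer chain of compound 1.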